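A few compounds are considered here, and "the series" means these few. Any claim that something is new, unique, unknown or untested is made for them only; others in the source may bear on it.

Working notes on the series, with the half-maximal inhibitory concentration as the read-out in a functional assay on CWR22R cells (Homo sapiens) for antiproliferative activity, read by CCK-8 assay, with a stated time of 6 days; on this read-out higher numbers stand for weaker inhibition and lower numbers for stronger inhibition. In this read-out compound 1 `COc1ccc(C(=O)N[C@@H](C)Cn2ccc(-c3ccc(C#N)c(Cl)c3)n2)cc1` carries the entry "not determined" (no result reported), so it offers no number for comparison. Compound 2 `C[C@@H](Cn1ccc(-c2ccc(C#N)c(Cl)c2)n1)Nc1ccccc1` gives > 30000 nM, which is a limit of the assay and not a number. Within the data shown here, the series therefore has no single value to anchor on and no measured step. Compound 3 `C[C@@H](Cn1ccc(-c2ccc(C#N)c(Cl)c2)n1)Nc1ncccn1` has pyrimidin-2-yl in place of phenyl on an amine nitrogen. Among the measured compounds shown here, with no measured step to size this change, only a small shift toward stronger inhibition is expected in this assay, and another limit remains quite possible. The expected step of an at least 1.2-fold lower number from compound 2 to compound 3 (0.07 log units; that floor lies within the scatter) is an estimate with wide uncertainty. Compound 3 is expected at about 25000 nM, with an estimated range of 6000 nM to 60000 nM.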

Compound 3, half-maximal inhibitory concentration: 12500 nM
Compound 3: the middle estimate sits 2.0-fold (0.30 log units) above what was measured, within the range that was stated.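

Compound 3 gives the series its first single number in this assay, so a change of the ring on the amine nitrogen is now shown to move the reading. Setting pyrimidin-2-yl in place of phenyl at this position gives an at least 2.4-fold lower number from compound 2 to compound 3 (0.38 log units; beyond the scatter). That step is a floor and not a full size, as its starting point for compound 2 is a limit of the assay and not a number: the limit of > 30000 nM in this assay, at which 1 of the 3 values shown sits.

The compounds shown leave open whether a single ring nitrogen, as in pyridin-2-yl, would give a similar reading, and whether a methyl group on the amine nitrogen would be tolerated. Compound 1 has no reported result, so steps involving its 4-methoxybenzamide cannot be read.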